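The compounds below may be only part of what the source reports. "The series", "measured", "known", "first", "only" and "open" are said of these compounds alone.

Compound 1 `COc1ccc(S(=O)(=O)N2CCc3cccc(NC(=O)c4ccncc4)c32)cc1` gives 9.6 nM in a functional assay on KB cells (Homo sapiens) for cytotoxicity; on this read-out lower numbers stand for stronger inhibition and higher numbers for weaker inhibition
Compound 2 `COc1ccc(C(=O)Nc2cccc3c2N(S(=O)(=O)c2ccc(OC)cc2)CC3)cc1` gives 2600 nM in this assay

Compound 2 has the higher number of the two. Going by the values given here, the only measured step of a 270-fold higher number from compound 1 to compound 2 (2.43 log units; beyond the scatter) is large and puts 4-methoxyphenyl in place of pyridin-4-yl on a carbonyl carbon. Compound 3 `COc1ccc(S(=O)(=O)N2CCc3cccc(NC(=O)c4ccc(C#N)cc4)c32)cc1` differs from compound 2 by cyano in place of methoxy on an aromatic carbon and has cyano in place of methoxy on an aromatic carbon. It keeps the carbon-only ring of compound 2, so only part of the step of a 270-fold higher number from compound 1 to compound 2 (2.43 log units; beyond the scatter) is expected to be recovered, towards a lower number in this assay overall. The expected size is an 8.7-fold lower number from compound 2 to compound 3 (0.94 log units; beyond the scatter) as an estimate. Compound 3 is expected at 300 nM within an estimated range from 40 nM to 2500 nM for now.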

Compound 3, half-maximal inhibitory concentration: 105 nM
The estimate for compound 3 lay 2.9-fold (0.46 log units) above the measured number; measured number inside the range.
By their numbers in this assay, from the lowest: compound 1; then compound 3; then compound 2.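

On the six-membered aromatic ring of carbon only, para to a large group, the choice of group carries much of the effect: in this assay, cyano in place of methoxy gives a 25-fold lower number from compound 2 to compound 3 (1.39 log units; beyond the scatter) on this read-out, so keeping a carbon-only ring does not by itself fix the number near that of compound 2. Pyridin-4-yl still stands apart, since 4-cyanophenyl in its place gives an 11-fold higher number from compound 1 to compound 3 (1.04 log units; beyond the scatter) in the same read-out. Nothing measured here explains either step.

From the compounds shown here alone, whether an amino group or a carboxylic acid at this place would fall nearer compound 3 or compound 2 stays open. So does whether pyridin-3-yl would match pyridin-4-yl.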